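Swapping the amide substituent in a weak cytotoxic series

The source may hold more compounds than are shown below. What is called first, only, known or untested is meant among the compounds shown, and "the series" means these compounds.

Compound 1 `CCc1ccc(NC(=O)c2cccc(/C=C3\CC(=O)N(c4ccccc4)C3=O)c2)cc1` gives in an ADME assay on SW480 cells (Homo sapiens) for cytotoxicity, read by MTT assay, with a stated time of 72 h (a lower number here means a stronger inhibitor, a higher number a weaker inhibitor), only a limit, > 100000 nM.
Compound 2 `Cc1ccc(NC(=O)c2cccc(/C=C3\CC(=O)N(c4ccccc4)C3=O)c2)cc1C` gives in this assay only a limit, > 100000 nM.
Compound 3 `CCc1cccc(NC(=O)c2cccc(/C=C3\CC(=O)N(c4ccccc4)C3=O)c2)c1` gives in this assay 88600 nM.

Among the compounds with values here, compound 3 holds the only number in this assay; the other two compounds sit at the limit of > 100000 nM in this assay, at which 2 of the 3 values shown sit. Compound 4 `O=C(c1cccc(/C=C2\CC(=O)N(c3ccccc3)C2=O)c1)N1CCCC1` differs from compound 3 by pyrrolidin-1-yl in place of (3-ethylphenyl)amino on a carbonyl carbon. The measured steps that touch the same amide position are an at least 1.1-fold lower number from compound 1 to compound 3 (0.05 log units; that floor lies within the scatter) and an at least 1.1-fold lower number from compound 2 to compound 3 (0.05 log units; that floor lies within the scatter), while a step that the two limits leave unreadable from compound 1 to compound 2. None of them shows a change beyond the scatter, so the step of a 1.1-fold higher number from compound 3 to compound 4 (0.05 log units; within the scatter) is expected to be small as well, in whichever direction. Compound 4 is therefore estimated at 100000 nM, within 40000 nM to 300000 nM, with a fair chance that only a limit is reported.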

Compound 4, half-maximal inhibitory concentration: > 100000 nM
Compound 4 was reported as a limit; the forecaster's own chance of this, stated with the estimate: 55%; the middle value lies on the limit itself.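

Exchanging the aromatic (3-ethylphenyl)amino group for the non-aromatic pyrrolidin-1-yl, which also removes the amide hydrogen, gives an at least 1.1-fold higher number from compound 3 to compound 4 (0.05 log units; that floor lies within the scatter), so this larger change on the carbonyl carbon still shows no measurable gain in cytotoxicity. The steps from compound 1 and compound 2 to compound 4 cannot be read. The series now gives mostly limits rather than numbers: the limit of > 100000 nM in this assay, at which 3 of the 4 values shown sit.

On these data alone, how far compound 4 truly lies from compound 3 stays open. So does whether a piperazine ring or a carboxylic acid at this carbonyl carbon would give a clearly lower number.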